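This account rests on a few compounds, and the source may have more. Where it says the series, first, only, none or still open, it means among the compounds named here.

Compound 1 `COc1ccc(CNc2nc3cc(N)cc(N)c3nc2-c2ccccc2)cc1OC`: in a functional assay on SK-OV-3 cells (Homo sapiens) for inhibition, read by sulforhodamine B assay, with a stated time of 48 h (a lower number here means that less compound is tolerated, a higher number that more compound is tolerated), compound 1 gives < 100000 nM, which is a limit of the assay.
Compound 2 `Nc1cc(N)c2nc(-c3ccccc3)c(NCc3ccc(F)cc3)nc2c1`: compound 2 gives 53700 nM.
Compound 3 `COc1ccc(CNc2nc3cc(N)cc(N)c3nc2-c2ccccc2)cc1`: compound 3 gives < 100000 nM, again a limit of the assay.

For the measured compounds named here, compound 2 therefore stands as the only compound of the three with a number in this assay; the other two sit at the limit of < 100000 nM in this assay, at which 2 of the 3 values shown sit. The steps around it, a step that the limit leaves unreadable from compound 1 to compound 2 and a step that the limit leaves unreadable from compound 2 to compound 3, cannot be sized for the same reason, and the step that the two limits leave unreadable from compound 1 to compound 3 is likewise unreadable.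

Compound 4 `Nc1cc(N)c2nc(-c3ccccc3)c(Oc3ccc(F)cc3)nc2c1` differs from compound 2 by 4-fluorophenoxy in place of (4-fluorobenzyl)amino on an aromatic carbon. Going by the values given here, none of the measured steps touches this part of the shared core, since all three measured compounds keep the (4-fluorobenzyl)amino or a related benzylamino group, so no measured step bears on this change and no direction can be drawn from the data. Compound 4 is therefore expected to remain close to compound 2, at an estimated 55000 nM with a range from 15000 nM to 150000 nM, which corresponds to an expected step of a 1.0-fold higher number from compound 2 to compound 4 (0.01 log units; within the scatter).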

Compound 4, concentration lethal to 50% of the cells: 83200 nM
Compound 4: the middle estimate sits 1.5-fold (0.18 log units) below what was measured; low and high end bracket the measured number.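

For the compounds shown here, compound 4 is the first change at this aromatic carbon, next to the ring nitrogen and ortho to a phenyl group, and it gives a second number in this assay to set beside that of compound 2. Exchanging (4-fluorobenzyl)amino for 4-fluorophenoxy, which gives up the hydrogen-bond donor counted in the group that leaves, produces a 1.5-fold higher number from compound 2 to compound 4 (0.19 log units; within the scatter), so the change has no readable effect on the number in this assay. Nothing measured here gives a cause for this outcome.

The compounds shown leave open whether a longer chain between this carbon and the 4-fluorophenyl ring, or a sulfur atom in place of the phenoxy oxygen, would shift the number beyond the scatter. They also leave open how an amine or a carboxylic acid on that ring would read.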